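A few compounds are considered here, and "the series" means these few. Any claim that something is new, unique, unknown or untested is made for them only; others in the source may bear on it.

In a functional assay on HOP-62 cells (Homo sapiens) for inhibition, read by sulforhodamine B assay, with a stated time of 48 h (on this read-out higher numbers stand for lower toxicity in this test and lower numbers for higher toxicity in this test), compound 1 `COc1ccc(-c2cc(/C=C/C(=O)c3ccc(N)cc3)[nH]n2)cc1` gives 61200 nM, while compound 2 `COc1cc(-c2cc(/C=C/C(=O)c3ccc(N)cc3)[nH]n2)cc(OC)c1OC` gives 8700 nM, the lowest of the two numbers, with compound 1 as its nearest neighbour and that gap lying beyond the scatter. Compound 3 `COc1cc(-c2cc(/C=C/C(=O)c3ccc(Cl)c(Cl)c3)[nH]n2)cc(OC)c1OC` has not yet been measured; it differs from compound 2 in one place: 3,4-dichlorophenyl in place of 4-aminophenyl on a carbonyl carbon. Within the data shown here, no measured pair shows this particular change, so its effect is unknown. The expected step is a 1.0-fold higher number from compound 2 to compound 3 (0.01 log units; within the scatter), a change estimated to remain within the scatter. Compound 3 is therefore estimated at 9000 nM, expected between 2500 nM and 35000 nM.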

Compound 3, concentration lethal to 50% of the cells: 42600 nM
For compound 3 the middle estimate is 4.7-fold (0.68 log units) below the measured one; measured number outside the range, above it.
By their numbers in this assay, from the lowest: compound 2; then compounds 3 and 1 (each within the scatter of the next).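

In this assay the group on the carbonyl carbon proves able to move the number: 3,4-dichlorophenyl in place of 4-aminophenyl gives a 4.9-fold higher number from compound 2 to compound 3 (0.69 log units; beyond the scatter) and so lower toxicity in this test. Compound 1 and compound 2 both carry 4-aminophenyl there, so neither could show this. Nothing at hand explains the shift. Going by these compounds, the swap removes the amine and adds two chlorines at once, so it stays open which of these matters. A plain phenyl or a 4-chlorophenyl at this place would help separate them.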